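The source may hold more compounds than are shown below. What is called first, only, known or untested is meant among the compounds shown, and "the series" means these compounds.

Working notes on the series in a toxicity assay on BJ cells (Homo sapiens) for cytotoxicity, read by MTT assay, with a stated time of 24 h; on this read-out lower numbers stand for stronger inhibition and higher numbers for weaker inhibition. Compound 1 `CCOC(=O)N1CCC(=NNC(=O)c2ccc(F)cc2)CC1`, compound 2 `CCOC(=O)N1CCC(=NNC(=O)c2ccc(C)cc2)CC1` and compound 3 `CCOC(=O)N1CCC(=NNC(=O)c2ccc(C(F)(F)F)cc2)CC1` share a core and differ in one aromatic substituent: fluoro, methyl and trifluoromethyl. Compound 1 gives > 400000 nM, which is a limit of the assay. Compound 3 gives > 400000 nM, also a limit. Compound 2 gives > 400000 nM, again a limit and not a number. Among the compounds with values here, the series so far shows (the limit of > 400000 nM in this assay, at which 3 of the 3 values shown sit).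

The next compound is compound 4 `CCOC(=O)N1CCC(=NNC(=O)c2ccc([N+](=O)[O-])cc2)CC1`, which differs from compound 2 as follows: nitro in place of methyl on an aromatic carbon. Within the data shown here, three measured steps bear on this swap: a step that the two limits leave unreadable from compound 1 to compound 2, a step that the two limits leave unreadable from compound 1 to compound 3 and a step that the two limits leave unreadable from compound 2 to compound 3. None of them gives a size, so no size or direction carries over to the nitro group, and the closest guide is the limit of compound 2 at > 400000 nM. The expected change is a step that the limit leaves unreadable from compound 2 to compound 4, with no step beyond the scatter foreseen and a further limit the likeliest report. For compound 4 the estimated value is 450000 nM, with an expected range from 200000 nM to 1000000 nM.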

Compound 4, half-maximal inhibitory concentration: > 400000 nM
Compound 4: only a limit was reported; the forecaster's own chance of this, stated with the estimate: 75%; the middle value is on the limit's open side.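

In this assay compound 4 gives > 400000 nM, which is a limit and not a number. Within the data shown here, no step between compound 4 and compound 1, compound 2 or compound 3 can therefore be read. The compounds shown leave open whether any aromatic substituent on the shared core gives a readable value: the limit of > 400000 nM in this assay, at which 4 of the 4 values shown sit.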